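Changing the amide on a benzimidazole-type core: compound 1 to compound 4

The source may hold more compounds than are shown below. What is called first, only, known or untested is meant among the compounds shown, and "the series" means these compounds.

Measured so far:
- compound 1, `CCN(CC)C(=O)[C@H]1CC[C@@H](n2/c(=N/C(=O)c3ccccc3)[nH]c3ccc(CN4CCCCC4)cc32)CC1`: 682 mL.min-1.g-1
- compound 2, `CC(C)NC(=O)[C@H]1CC[C@@H](n2/c(=N/C(=O)c3cccnc3)[nH]c3ccc(CN4CCC(C(C)(C)O)CC4)cc32)CC1`: < 14 mL.min-1.g-1
- compound 3, `C=CCNS(=O)(=O)c1cccc(C(=O)/N=c2\[nH]c3cc(CN4CCCCC4)ccc3n2[C@H]2CC[C@@H](CO)CC2)c1`: 314 mL.min-1.g-1

Of the compounds shown here, three that share one core have been tested in an in vitro ADME assay on microsomes from liver (Rattus norvegicus) for metabolic stability; a lower number here means slower removal, a higher number faster removal of the compound. Compound 1 gives 682 mL.min-1.g-1, the highest of the two numbers shown. Compound 3 gives 314 mL.min-1.g-1, a value beyond the scatter below that of compound 1. For compound 2 the assay reports only a limit, < 14 mL.min-1.g-1, not a number; this is the limit of < 14 mL.min-1.g-1 in this assay, at which 1 of the 3 values shown sits.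

Compound 4, `CC(C)NC(=O)[C@H]1CC[C@@H](n2/c(=N/C(=O)c3ccccc3)[nH]c3ccc(CN4CCCCC4)cc32)CC1`, has not yet been measured in this assay. It differs from compound 1 in a single place: isopropylamino in place of diethylamino on a carbonyl carbon. Everything else in the structure, including the core and the piperidinylmethyl group, is kept. No measured pair of compounds differs only in this way, so the size of the step cannot be read off directly from the values at hand, and no cause can be given for whatever shift appears.

Weighing the values that are known, a drop in intrinsic clearance is expected for compound 4, a step of a 2.7-fold lower number from compound 1 to compound 4 (0.44 log units; beyond the scatter). Compound 4 is therefore estimated at 250 mL.min-1.g-1 in this assay, with a range from 80 mL.min-1.g-1 to 700 mL.min-1.g-1.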

Compound 4, intrinsic clearance in microsomes: 389 mL.min-1.g-1
Estimate against measurement, compound 4: 1.6-fold (0.19 log units) below, and the stated range covers the measured number.
By their numbers in this assay, from the lowest: compounds 3, 4 and 1 (each within the scatter of the next, the first and the last beyond it). At a limit, below all of these: compound 2.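

In this assay, putting isopropylamino in place of diethylamino on a carbonyl carbon gives a 1.8-fold lower number from compound 1 to compound 4 (0.24 log units; within the scatter), and both compounds keep the rest of the structure unchanged. This is the first pair shown that differs in one place only, so the size of this change can now be read directly instead of being inferred from compounds that differ in several places. Isopropylamino carries a hydrogen-bond donor and diethylamino carries none, yet the two numbers cannot be told apart in this assay, so in this single pair, exchanging these two amide groups leaves no measurable mark on the clearance.

On these data alone, whether a different group on the same carbonyl carbon, such as methylamino, or a carboxylic acid in place of the whole amide, would move the number beyond the scatter remains open, as does whether the same exchange would look alike with other groups elsewhere on the shared core. For the compounds shown here, nothing measured so far speaks to why compound 1 and compound 4 match so closely.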